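A few compounds are considered here, and "the series" means these few. Any claim that something is new, unique, unknown or untested is made for them only; others in the source may bear on it.

Measured in a physicochemical assay for solubility, in simulated intestinal fluid, at pH 7.4; a lower number here means a less soluble compound, a higher number a more soluble compound:

- compound 1 `COc1ccncc1C(=O)NC(=O)Nc1ccc(-c2ccccc2)c(C(F)(F)F)c1`: 16 ug/mL
- compound 2 `Cn1cc(C(=O)Nc2ccc(-c3ccccc3)c(C(F)(F)F)c2)c(=O)c2ccccc21`: 11 ug/mL
- compound 3 `Cn1cc(C(=O)Nc2ccc(-c3ccccc3)c(C(F)(F)F)c2)c(=O)c2cccnc21`: 5.9 ug/mL

Compound 2 lies within the usual scatter of both compound 1 and compound 3, so these numbers do not separate it from either neighbour. The next compound to be measured is compound 4 (`Cn1cc(C(=O)Nc2ccc(-c3ccccn3)c(C(F)(F)F)c2)c(=O)c2ccccc21`), which differs from compound 2 in one place: pyridin-2-yl in place of phenyl on an aromatic carbon. In words, this is pyridin-2-yl in place of phenyl on an aromatic carbon.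

For the measured compounds named here, no two measured compounds differ in just one place, so no measured step shows what this swap does. The expectation therefore starts from compound 2 at 11 ug/mL and allows only a modest move, with a slight lean upward and no firm claim on direction. The expected step is a 1.3-fold higher number from compound 2 to compound 4 (0.10 log units; within the scatter), which would not clearly stand beyond the scatter. For compound 4 the estimated value is 14 ug/mL, with an expected range from 5 ug/mL to 40 ug/mL.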

Compound 4, solubility: 5.2 ug/mL
Compound 4: the middle estimate sits 2.7-fold (0.43 log units) above what was measured, within the range that was stated.
By their numbers in this assay, from the lowest: compounds 4, 3, 2 and 1 (each within the scatter of the next, the first and the last beyond it).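

In this assay, for the compounds shown here, pyridin-2-yl in place of phenyl gives a 2.1-fold lower number from compound 2 to compound 4 (0.33 log units; beyond the scatter) and this is the first step here that rests on a single change. It shows that at this aromatic carbon, ortho to a trifluoromethyl group, exchanging one ring carbon for nitrogen and so gaining one hydrogen-bond acceptor is enough to lower the number modestly, though the step stands only just beyond the scatter. The compounds shown offer no measurement that accounts for this step.

From the compounds shown here alone, whether pyridin-3-yl, pyridin-4-yl, or a phenyl ring carrying an amine or a carboxylic acid would move the number the same way remains open. Going by these compounds, it is also open whether this same swap would give a similar step on the core of compound 1 or compound 3.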